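Sulfonyl substituent changes and human microsomal clearance

The compounds below may be only part of what the source reports. "The series", "measured", "known", "first", "only" and "open" are said of these compounds alone.

Measured compounds:
compound 1, `O=C(NCc1ccc(S(=O)(=O)C2CCOCC2)cc1)N1Cc2ccncc2C1`; in an ADME assay on microsomes from liver (Homo sapiens) for pharmacokinetics, read by LC-MS, with a stated time of 60 min, tested at 1 uM (a higher number here means faster removal of the compound, a lower number slower removal), compound 1 gives 6 mL/min/kg
compound 2, `CCC(=O)N1CCC(S(=O)(=O)c2ccc(CNC(=O)N3Cc4ccncc4C3)cc2)CC1`; in this assay compound 2 gives 11 mL/min/kg
compound 3, `O=C(NCc1ccc(S(=O)(=O)N2CCC[C@H](O)C2)cc1)N1Cc2ccncc2C1`; in this assay compound 3 gives 8 mL/min/kg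

The three measured compounds share one core and differ only in the group on the sulfonyl sulfur. Their numbers in this assay sit close together: a 1.8-fold higher number from compound 1 to compound 2 (0.26 log units; within the scatter) and a 1.3-fold higher number from compound 1 to compound 3 (0.12 log units; within the scatter), and between the other two a 1.4-fold lower number from compound 2 to compound 3 (0.14 log units; within the scatter). Compound 1 is thus the reference point of the set, with neither neighbour separated from it by more than the scatter.

The next compound, compound 4, `O=C(NCc1ccc(S(=O)(=O)N2CCC(N3CCCC3)CC2)cc1)N1Cc2ccncc2C1`, is again a change at the same position: 4-(pyrrolidin-1-yl)piperidin-1-yl in place of oxan-4-yl on a sulfonyl sulfur. The two measured steps from compound 1 bear on it, since each also swaps the oxan-4-yl for a saturated nitrogen-containing ring, and both stayed within the scatter. Nothing in the set points to a step beyond the scatter in this assay in either direction, though the entering group is the largest tried so far, so a small rise cannot be excluded. Compound 4 is therefore estimated at 10 mL/min/kg, with a range of 5 mL/min/kg to 20 mL/min/kg, an expected step of a 1.7-fold higher number from compound 1 to compound 4 (0.22 log units; within the scatter).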

Compound 4, clearance: 6 mL/min/kg
Compound 4: middle estimate off by 1.7-fold (0.22 log units), on the high side; measured number inside the range.
By their numbers in this assay, from the lowest: compounds 1, 4, 3 and 2 (each within the scatter of the next).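

In this assay, the largest group tried so far on a sulfonyl sulfur, 4-(pyrrolidin-1-yl)piperidin-1-yl with 11 heavy atoms and two rings, replaces oxan-4-yl with its 6 heavy atoms and one ring without a step beyond the scatter (no change at the digits printed from compound 1 to compound 4 (within the scatter)). The same holds when it is set against the other two groups at this position (a 1.3-fold lower number from compound 3 to compound 4 (0.12 log units; within the scatter); a 1.8-fold lower number from compound 2 to compound 4 (0.26 log units; within the scatter)), so all four compounds now lie within the scatter of one another, and across these four neither the heavy-atom count nor the second ring of the entering group separates compound 4 from the others. No supporting measurement is available to explain why the numbers stay together.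

Every group shown on the sulfonyl sulfur contains a saturated ring, so it remains open whether an open-chain dimethylamino group, a phenyl ring or a group carrying a carboxylic acid would also stay within the scatter. The compounds shown also leave open whether a fluoro substituent elsewhere on the shared core would give a step beyond it.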